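From compound 2 to compound 3: a small step expected

The compounds below may be only part of what the source reports. "The series", "measured", "known", "first", "only" and "open" are said of these compounds alone.

compound 1 `Cc1c(C)c2c(c(C)c1OC(=O)CCC(=O)O)CCC(C)(C(=O)O)O2`: 120000 nM
compound 2 `Cc1c(C)c2c(c(C)c1OC(=O)CCC(=O)NC1CC(C)(C)N([O])C1(C)C)CCC(C)(C(=O)NC1CC(C)(C)N([O])C1(C)C)O2`: 75000 nM

In a functional assay on U-937 cells (Homo sapiens) for cytotoxicity, read by MTT assay, with a stated time of 72 h (a higher number here means a weaker inhibitor, a lower number a stronger inhibitor), only these two compounds have been measured, and compound 2 at 75000 nM stands within the scatter of compound 1 at 120000 nM. Compound 3 `Cc1c(C)c2c(c(C)c1OC(=O)CCC(=O)O)CCC(C)(C(=O)NC1CC(C)(C)N([O])C1(C)C)O2` differs from compound 2 by one oxygen atom in place of a group of 11 heavy atoms (8 carbon, 2 nitrogen, 1 oxygen; one five-membered non-aromatic ring with 1 hetero atom), on a carbonyl carbon on a carbonyl carbon, where a hydroxy enters. Within the data shown here, no measured pair isolates this change. Since the two known values lie so close, no step beyond the scatter is expected in this assay. The estimated step of a 1.3-fold higher number from compound 2 to compound 3 (0.10 log units; within the scatter) is therefore small. Compound 3 is expected at 95000 nM, within an estimated range of 45000 nM to 190000 nM.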

Compound 3, half-maximal inhibitory concentration: 163000 nM
Beside the measured number, compound 3's estimate is 1.7-fold (0.23 log units) below it; measured number inside the range.
By their numbers in this assay, from the lowest: compounds 2, 1 and 3 (each within the scatter of the next, the first and the last beyond it).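

In this assay, among these compounds, a hydroxy in place of the group of 11 heavy atoms, on a carbonyl carbon whose other neighbours are a saturated chain carbon, gives a 2.2-fold higher number from compound 2 to compound 3 (0.34 log units; beyond the scatter) and is the first step here beyond the scatter, a modest one. The same group in place of one oxygen atom, on a carbonyl carbon, gives only a 1.4-fold higher number from compound 1 to compound 3 (0.13 log units; within the scatter) and stays within the scatter, so that change does not separate these two compounds. Nothing available explains this difference between the two steps.

On these data alone, whether an amine or a methyl ester on this carbonyl carbon would give a value like that of compound 2 or compound 3 stays open. Also open, as far as these compounds go, is whether a simple amide without the five-membered ring would match the group of 11 heavy atoms.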